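Dienone chain extension in a growth inhibition series

The compounds below may be only part of what the source reports. "The series", "measured", "known", "first", "only" and "open" are said of these compounds alone.

Measured in a functional assay on MDA-MB-231 cells (Homo sapiens) for inhibition; a lower number here means a stronger inhibitor of growth, a higher number a weaker inhibitor of growth:
compound 1 `C/C=C/C=C/C(=O)C[C@H](CCO)OC`: 30000 nM
compound 2 `C/C=C/C=C/C(=O)CC(CCO)OCC[C@H](O)CC(=O)CC/C=C/C`: 28000 nM

Compound 2, at 28000 nM, stands level with compound 1, at 30000 nM. Among the compounds with values here, the two values lie within the scatter of each other, so neither ranks ahead, and both are the only numbers available for this series. Compound 3 `C/C=C/C=C/C(=O)CC(CCO)OCC[C@H](O)CC(=O)/C=C/C=C/C` remains to be measured. It carries penta-1,3-dien-1-yl in place of pent-3-en-1-yl on a carbonyl carbon. Within the data shown here, no measured pair isolates this change, so the expectation rests on little. A small move toward stronger growth inhibition is expected in this assay, close to the edge of the scatter, and no change at all would not surprise. The expected size of the move is a 1.6-fold lower number from compound 2 to compound 3 (0.19 log units; within the scatter). For compound 3 the estimated value is 18000 nM, with an expected range of 6000 nM to 40000 nM.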

Compound 3, concentration for 50% growth inhibition: 29000 nM
Estimate against measurement, compound 3: 1.6-fold (0.21 log units) below; the measured number falls inside the stated range.
By their numbers in this assay, from the lowest: compounds 2, 3 and 1 (each within the scatter of the next).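

In this assay, within the data shown here, the first pair to isolate this position gives a 1.0-fold higher number from compound 2 to compound 3 (0.02 log units; within the scatter), which lies within the scatter. With penta-1,3-dien-1-yl in place of pent-3-en-1-yl on a carbonyl carbon, the added double bond outside aromatic rings leaves the read-out level, so these two chains cannot be told apart in this assay. No measurement at hand bears on why the step has this size.

The compounds shown leave open whether any group at this carbonyl carbon can shift growth inhibition, as they cover only these two hydrocarbon chains. An amine, a carboxylic acid or a longer chain in this place would be needed to show whether the position responds at all.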